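Swapping bromine for iodine on a thiourea cytotoxicity pair

A few compounds are considered here, and "the series" means these few. Any claim that something is new, unique, unknown or untested is made for them only; others in the source may bear on it.

Measured compounds:
- compound 1, `S=C(Nc1ccccc1)Nc1nc[nH]n1`: > 100000 nM in an ADME assay on MT4 cells (Homo sapiens) for cytotoxicity, read by MTT assay, with a stated time of 96 h; a lower number here means that less compound is tolerated, a higher number that more compound is tolerated
- compound 2, `S=C(Nc1ccc(Br)cc1)Nc1nc[nH]n1`: > 100000 nM in this assay

Compound 2 stands at a limit of this assay rather than at a number: its value of > 100000 nM only says that no half-maximal cytotoxic concentration was reached within the tested range. Compound 1 also sits at a limit, > 100000 nM, so the step that the two limits leave unreadable from compound 1 to compound 2 cannot be read; what is known is the limit of > 100000 nM in this assay, at which 2 of the 2 values shown sit.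

Compound 3, `S=C(Nc1ccc(I)cc1)Nc1nc[nH]n1`, differs from compound 2 by iodo in place of bromo on an aromatic carbon. Within the data shown here, the only measured step that bears on a change of halogen at this place is the one from compound 1 to compound 2, and its size is not readable. There is therefore no measured basis for expecting a shift beyond the scatter in either direction.

Compound 3 is expected to remain at the same limit, with an estimate of 100000 nM and a range from 50000 nM to 200000 nM. The step this implies, a number no higher from compound 2 to compound 3 (the limit leaves the size open), is expected to be none beyond the scatter.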

Compound 3, half-maximal cytotoxic concentration: 46000 nM
Compound 3: middle estimate off by 2.2-fold (0.34 log units), on the high side, and the stated range ends above it.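

Among these compounds, the iodo group is the first change here to bring a half-maximal cytotoxic concentration into view in this assay, so the halogen at this place on the ring does matter for how much compound the cells tolerate. Iodo in place of bromo gives an at least 2.1-fold lower number from compound 2 to compound 3 (0.33 log units; beyond the scatter), and iodo in place of hydrogen gives an at least 2.1-fold lower number from compound 1 to compound 3 (0.33 log units; beyond the scatter), so both changes take the number down beyond the scatter. The step from hydrogen to bromo still cannot be read, and the two new steps give only minimum sizes, as neither starting compound has an exact number: the limit of > 100000 nM in this assay, at which 2 of the 3 values shown sit.

The compounds shown carry only hydrogen, bromo or iodo at this place, so what an amine, a carboxylic acid or a methoxy group would do there stays open. On these data alone, whether iodo on another carbon of the same ring would lower the number in this assay also stays open.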